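This account rests on a few compounds, and the source may have more. Where it says the series, first, only, none or still open, it means among the compounds named here.

Measured in a functional assay on HL-60 cells (Homo sapiens) for inhibition, read by MTT assay, with a stated time of 48 h, tested at 10 uM; on this read-out higher numbers stand for more inhibition of growth at the one concentration tested and lower numbers for less inhibition of growth:
- compound 1 `Cc1oc2c([C@H]3CCN(C)C[C@H]3O)c(O)cc(O)c2c(=O)c1C(O)c1ccc([N+](=O)[O-])cc1`: 0%
- compound 2 `Cc1oc2c([C@H]3CCN(C)C[C@H]3O)c(O)cc(O)c2c(=O)c1C(O)c1cccc(Cl)c1`: 22%
- compound 3 `Cc1oc2c([C@H]3CCN(C)C[C@H]3O)c(O)cc(O)c2c(=O)c1C(O)c1ccccc1Br`: 52%

Compound 3 stands highest of the three, at 52%, and both gaps below it lie beyond the scatter: a number 30 percentage points higher from compound 2 to compound 3 (beyond the scatter), and a number 52 percentage points higher from compound 1 to compound 3 (beyond the scatter). The next compound, compound 4 `Cc1oc2c([C@H]3CCN(C)C[C@H]3O)c(O)cc(O)c2c(=O)c1C(O)c1ccc(F)c(Br)c1`, has not yet been measured. It carries 3-bromo-4-fluorophenyl in place of 2-bromophenyl, on a saturated chain carbon bound to an aromatic carbon and an oxygen on a saturated carbon (3-bromo-4-fluorophenyl in place of 2-bromophenyl on a saturated chain carbon bound to an aromatic carbon and an oxygen on a saturated carbon).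

All three measured steps exchange the aryl group at this same place, so all of them bear on the change. The closest guide is compound 2, whose 3-chlorophenyl gives 22%. Compound 1, with 4-nitrophenyl, gives 0%. Only compound 3 has 2-bromophenyl, and compound 4 gives that group up. Going by the values given here, no measured compound has a fluorine, so the data leave that part of the change untested. A modest fall in this assay is therefore expected, and the expected step is a number 22 percentage points lower from compound 3 to compound 4 (beyond the scatter). For compound 4 the estimated value is 30%, with an expected range of 10% to 55%.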

Compound 4, percent growth inhibition at one concentration: 25%
For compound 4 the middle estimate is 5 percentage points above the measured one; low and high end bracket the measured number.
By their numbers in this assay, from the lowest: compound 1; then compounds 2 and 4 (each within the scatter of the next); then compound 3.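

In this assay, going by these compounds alone, the step to 3-bromo-4-fluorophenyl is a number 27 percentage points lower from compound 3 to compound 4 (beyond the scatter), which shows that carrying a bromine on the aryl group does not by itself keep the level of compound 3, and 2-bromophenyl remains the only group here that stands apart from all the others. The same new group set against 3-chlorophenyl gives a number 3 percentage points higher from compound 2 to compound 4 (within the scatter), and set against 4-nitrophenyl it gives a number 25 percentage points higher from compound 1 to compound 4 (beyond the scatter), so two differently substituted aryl groups now share one level at this place on a saturated chain carbon, while 4-nitrophenyl stays apart from them. No measurement shown here offers a reason for these steps.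

From the compounds shown here alone, the step from compound 3 to compound 4 alters the place of the bromine and adds a fluorine in a single change, so the part played by each stays open, and plain 3-bromophenyl, 4-fluorophenyl or 2-chlorophenyl would be needed to separate them. Also open, going by these compounds, is how this place responds to a group other than a substituted phenyl, such as a pyridine ring, an amine or a longer alkyl chain.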